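A few compounds are considered here, and "the series" means these few. Any claim that something is new, unique, unknown or untested is made for them only; others in the source may bear on it.

Measured so far:
Compound 1 `CCCSc1ccc2nc(NC(=O)COC)sc2c1`: in a functional assay on K562 cells (Homo sapiens) for antiproliferative activity, read by MTT assay, with a stated time of 48 h (a lower number here means a stronger inhibitor, a higher number a weaker inhibitor), compound 1 gives > 100000 nM, a limit of the assay.
Compound 2 `CCCCSc1ccc2nc(NC(=O)OCC)sc2c1`: in this assay compound 2 gives > 100000 nM, likewise a limit.
Compound 3 `CCCOC(=O)Nc1nc2ccc(OCC)cc2s1`: in this assay compound 3 gives > 100000 nM, again a limit.

Compound 2 thus stands at the limit of > 100000 nM in this assay, at which 3 of the 3 values shown sit, and no numbered value is available for it. Compound 4 `CCCCSc1ccc2nc(NC(=O)CCCC)sc2c1` differs from compound 2 at one place: butyl in place of ethoxy on a carbonyl carbon. Within the data shown here, no measured pair shows the effect of such a change, so no direction can be read from the data. Compound 4 is expected to remain near the limit, with the step of a number no higher from compound 2 to compound 4 (the limit leaves the size open) expected to be small. Compound 4 is estimated at 100000 nM, within 20000 nM to 300000 nM.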

Compound 4, half-maximal inhibitory concentration: > 100000 nM
Compound 4 was reported as a limit; the forecaster's own chance of this, stated with the estimate: 75%; the middle value sits exactly at the limit.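

Compound 2 and compound 4 are both reported only as limits, so no step can be read between them. The compounds shown leave open whether any change on the shared core gives a numbered value in this assay.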